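A few compounds are considered here, and "the series" means these few. Any claim that something is new, unique, unknown or untested is made for them only; others in the source may bear on it.

Of the compounds shown here, three built on a shared core have been tested for how strongly they hold back the growth of a human colon-cancer cell line. Compound 1 `Cc1ccc(NC(=S)NC(=O)c2ccc(OCc3ccccc3Cl)cc2)cc1-c1nc2ccccc2[nH]1` and compound 2 `Cc1ccc(NC(=S)NC(=O)c2ccc(OCc3ccc(Cl)c(Cl)c3)cc2)cc1-c1nc2ccccc2[nH]1` share one core; compound 3 `Cc1ccc(NC(=O)NC(=O)c2ccc(OCc3ccccc3Cl)cc2)cc1-c1nc2ccccc2[nH]1` and compound 4 `Cc1ccc(NC(=O)NC(=O)c2ccc(OCc3ccc(Cl)c(Cl)c3)cc2)cc1-c1nc2ccccc2[nH]1` share another, and the difference between the two cores is not broken down here. In a functional assay on SW-620 cells (Homo sapiens) for inhibition, read by MTT assay, with a stated time of 48 h (on this read-out higher numbers stand for weaker inhibition and lower numbers for stronger inhibition), compound 1 gives 57100 nM, compound 2 gives 30700 nM, and compound 3 gives 35700 nM.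

Between compound 1 and compound 2 the single change is 3,4-dichlorophenyl in place of 2-chlorophenyl on a saturated chain carbon bound to an oxygen on an aromatic ring. That change made a 1.9-fold lower number from compound 1 to compound 2 (0.27 log units; within the scatter), a step too small to count as a real difference. The same change is now made on the other core: compound 4 differs from compound 3 by 3,4-dichlorophenyl in place of 2-chlorophenyl on a saturated chain carbon bound to an oxygen on an aromatic ring. Among the measured compounds shown here, since the place of the change is the same in both pairs, the earlier step is the only guide, and its modest size suggests that compound 4 is expected to move from compound 3 by about a 1.6-fold lower number from compound 3 to compound 4 (0.21 log units; within the scatter). On that basis compound 4 is estimated to give 22000 nM in this assay, with a likely range from 9000 nM to 50000 nM, resting on compound 3 at 35700 nM and on the step seen with compound 1 and compound 2.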

Compound 4, half-maximal inhibitory concentration: 6100 nM
Compound 4: middle estimate off by 3.6-fold (0.56 log units), on the high side; the whole stated range lies above it.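

In this assay, putting 3,4-dichlorophenyl in place of 2-chlorophenyl on the core of compound 3 gave a 5.9-fold lower number from compound 3 to compound 4 (0.77 log units; beyond the scatter), a real gain in inhibition, whereas the same swap on the core of compound 1 made no difference that could be told from the scatter. Among the compounds shown here, the size of the step therefore did not carry over from one core to the other: the same change on two cores in this assay, a 1.9-fold lower number (0.27 log units; within the scatter) from compound 1 to compound 2 and a 5.9-fold lower number (0.77 log units; beyond the scatter) from compound 3 to compound 4, 3.1-fold (0.50 log units) apart, beyond the scatter of two such steps This shows that, in these four compounds, the effect of the change depends on the core it is made on, but with only one pair on each core it does not show why, or whether other changes would behave the same way.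

The compounds shown leave open how a phenyl ring carrying a methoxy group or a nitrile in place of the chlorines would behave on either core. They also leave open what a longer chain in place of the single saturated chain carbon would do.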